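Shortening the amide side chain: from propyl to ethyl

This account rests on a few compounds, and the source may have more. Where it says the series, first, only, none or still open, it means among the compounds named here.

Measured compounds:
compound 1 `CC[C@@H]1C(=O)N(C)c2cnc(-n3ccc4cc(C(=O)NCC(C)C)ccc43)nc2N1C1CCCC1`: "not active" (no number reported)
compound 2 `CC[C@@H]1C(=O)N(C)c2cnc(-n3ccc4cc(C(=O)NC5CCCC5)ccc43)nc2N1C1CCCC1`: 259 nM
compound 3 `CCCNC(=O)c1ccc2c(ccn2-c2ncc3c(n2)N(C2CCCC2)[C@H](CC)C(=O)N3C)c1`: 689 nM

The three compounds share one core and differ only in the group on the amide-type nitrogen. In a functional assay on Huh-7 cells (Homo sapiens) for antiproliferative activity, read by CCK-8 assay, with a stated time of 72 h (on this read-out lower numbers stand for stronger inhibition of growth and higher numbers for weaker inhibition of growth), compound 1 is recorded as "not active" (no number reported), so it provides no number. Compound 2 gives 259 nM, and compound 3 gives 689 nM. Among the compounds with values here, compound 3 thus holds the highest of the two numbers, with compound 2 the nearest, and the one step between them is a 2.7-fold higher number from compound 2 to compound 3 (0.42 log units; beyond the scatter).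

Compound 4 `CCNC(=O)c1ccc2c(ccn2-c2ncc3c(n2)N(C2CCCC2)[C@H](CC)C(=O)N3C)c1` has not been measured. It differs from compound 3 by hydrogen in place of methyl on a saturated chain carbon, two bonds along the chain from an amide-type nitrogen. Within the data shown here, the step that bears on this is the one from compound 2 to compound 3, where a smaller group on the amide-type nitrogen gave a modest rise; no other measured pair speaks to the amide substituent. Taking that step as a guide, compound 4 is expected to give a number somewhat higher than compound 3, at a step of about a 1.7-fold higher number from compound 3 to compound 4 (0.24 log units; within the scatter), though this could fall within the scatter. The estimate for compound 4 in this assay is 1200 nM, with a range from 500 nM to 3500 nM.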

Compound 4, concentration for 50% growth inhibition: 596 nM
Compound 4: middle estimate off by 2.0-fold (0.30 log units), on the high side; low and high end bracket the measured number.
By their numbers in this assay, from the lowest: compound 2; then compounds 4 and 3 (each within the scatter of the next).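

In this assay, within the data shown here, cutting the propyl chain back to ethyl leaves the read-out essentially unmoved, with a 1.2-fold lower number from compound 3 to compound 4 (0.06 log units; within the scatter), so at this position the loss of the terminal methyl makes no readable difference, something the single earlier step could not show. The ethyl amide also stands apart from the cyclopentyl amide, with a 2.3-fold higher number from compound 2 to compound 4 (0.36 log units; beyond the scatter), so the gap first seen with the propyl amide is now seen with a second straight chain, while compound 1, with its branched chain, is recorded as "not active" (no number reported) and cannot be placed on this scale. Nothing given here accounts for these numbers, and the size of the group alone does not order them.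

The compounds shown leave open whether a methyl on the amide nitrogen or the unsubstituted primary amide would follow the ethyl and propyl amides, and whether a cyclobutyl or cyclohexyl ring would match or pass the cyclopentyl of compound 2. They also leave open why the branched chain of compound 1 stands apart from the straight chains.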